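A few compounds are considered here, and "the series" means these few. Any claim that something is new, unique, unknown or untested is made for them only; others in the source may bear on it.

Measured compounds in the series:
- compound 1, `Cc1ccc(Sc2cnc(Nc3ccccn3)s2)cc1C(=O)NCC#N`: 44 nM
- compound 2, `Cc1ccc(Sc2cnc(Nc3cccc(Br)n3)s2)cc1C(=O)N(C)CC#N`: 2 nM

In an assay on isolated protein for inhibition of high affinity nerve growth factor receptor (Homo sapiens) (a higher number here means a weaker inhibitor, a lower number a stronger inhibitor), compound 2 gives 2 nM and stands lowest of the two numbers; compound 1 gives 44 nM in this assay, a higher number that lies beyond the usual scatter. For the measured compounds named here, the two differ in more than one place, so no single step is set out between them, and only the two values themselves can be read.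

Compound 3, `CCC(=O)N1CCN(C(=O)c2cc(Sc3cnc(Nc4cccc(Br)n4)s3)ccc2C)CC1`, keeps the shared core of compound 2 and differs from it in one place: 4-propanoylpiperazin-1-yl in place of (cyanomethyl)(methyl)amino on a carbonyl carbon. The tertiary amide is kept, the substituent on the amide nitrogen is larger and carries its acceptor in a second carbonyl. Going by the values given here, no measured step of this kind exists, so the direction is taken from the position of compound 2 alone. The expectation is a modest rise in number, so a weaker inhibitor, the step of a 3.0-fold higher number from compound 2 to compound 3 (0.48 log units; beyond the scatter) from compound 2 to compound 3 being the estimate. For compound 3 the estimated value in this assay is 6 nM, within a range of 1.5 nM to 30 nM.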

Compound 3, half-maximal inhibitory concentration: 21 nM
Compound 3: middle estimate off by 3.5-fold (0.54 log units), on the low side; measured number inside the range.
By their numbers in this assay, from the lowest: compound 2; then compound 3; then compound 1.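

Notes on the amide substituent, read in this assay: the group on the carbonyl carbon is now seen to affect the number, since 4-propanoylpiperazin-1-yl in place of (cyanomethyl)(methyl)amino gives an 11-fold higher number from compound 2 to compound 3 (1.02 log units; beyond the scatter), a large step and the first in the series that changes only one place. The step shows that this position accepts a group with a six-membered non-aromatic ring and 10 heavy atoms at a clear cost, with compound 3 still at 21 nM, and the cost arises although the hydrogen-bond donor and acceptor counts of the leaving and entering groups are the same. No measurement available here accounts for the rise in the number.

For the compounds shown here, the single step removes the nitrile and brings in the ring and the propanoyl group together, so it remains open which of these changes goes with the rise; a morpholin-4-yl or a plain dimethylamino group on the same carbonyl carbon would help to separate them. From the compounds shown here alone, it also remains open whether a step of this size would recur on the core of compound 1, which carries no bromine.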